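This account rests on a few compounds, and the source may have more. Where it says the series, first, only, none or still open, it means among the compounds named here.

Working notes on the series. Three members of the shared core have been run in an assay on isolated protein for displacement of a labelled ligand from metabotropic glutamate receptor 5 (Homo sapiens), with a stated time of 60 min, tested at 1 uM; on this read-out lower numbers stand for less inhibition and higher numbers for more inhibition at the one concentration tested (going by the name of the read-out): compound 1 `CC1CCN(c2c(S(=O)(=O)c3cc(Cl)cc(Cl)c3)cnc3c(F)cccc23)CC1`, compound 2 `CC1CCN(c2c(S(=O)(=O)c3ccc(F)c(F)c3)cnc3ccc(Cl)cc23)CC1` and compound 3 `Cc1cc(C)cc(S(=O)(=O)c2cnc3cc(F)ccc3c2N2CCC(C)CC2)c1`. In this assay compound 1 gives 82%, compound 2 gives 72% and compound 3 gives 80%. Compound 1 carries the highest of the three numbers, but its nearest neighbour compound 3 sits only a little lower and even compound 2, the furthest of the three, lies within the usual scatter of repeat measurements, so no ordering among the three can be read from these numbers. Going by the values given here, no pair of measured compounds differs in a single place, so no isolated step is available to set the size of any change.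

The next compound, compound 4 `CC1CCN(c2c(S(=O)(=O)c3ccc(F)c(Cl)c3)cnc3c(F)cccc23)CC1`, is a direct variation of compound 1: 3-chloro-4-fluorophenyl in place of 3,5-dichlorophenyl on a sulfonyl sulfur. The change is confined to the aryl group on the sulfonyl sulfur, with the same heavy-atom count before and after. Among the compounds with values here, with no single-point step among the measured compounds to lean on, the step from compound 1 to compound 4 in this assay is expected to be small, at most a slight decrease, and is estimated at a number 6 percentage points lower from compound 1 to compound 4 (within the scatter). On that basis compound 4 is expected to give about 76% in this assay, estimated to fall between 62% and 88%.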

Compound 4, a percentage reported as inhibition, at one concentration (the size of the read-out at that concentration, not a potency): 95%
Compound 4: the middle estimate sits 19 percentage points below what was measured, and the stated range ends below it.
By their numbers in this assay, from the lowest: compounds 2, 3 and 1 (each within the scatter of the next); then compound 4.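

In this assay, going by these compounds alone, the aryl group on the sulfonyl sulfur proves able to move the read-out on its own, with a number 13 percentage points higher from compound 1 to compound 4 (beyond the scatter) as the only step that changes a single place. The two groups are alike in everything counted: each has 8 heavy atoms and one six-membered aromatic ring of carbon only, and neither has a hydrogen-bond donor, a hydrogen-bond acceptor or a net charge, so a step of this size can arise without any change in those counts. Nothing available bears on what lies behind the step.

Compound 2 and compound 3 each differ from compound 4 in more than one place, so it remains open whether 3-chloro-4-fluorophenyl would give a similar step on their versions of the shared core, and the read-out at one concentration gives no potency for any of these compounds. Also open, as far as these compounds go, is whether the number in this assay would be higher, lower or level with an aryl group carrying an amine or a carboxylic acid on the sulfonyl sulfur, or with a pyridyl ring in place of the phenyl ring.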